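Cyano on the phenyl of compound 1: cytotoxicity outlook

This account rests on a few compounds, and the source may have more. Where it says the series, first, only, none or still open, it means among the compounds named here.

Compound 1 `Cc1ccc(C2=NN(c3nc(-c4ccccc4)cs3)C(c3ccc(F)cc3)C2)s1` is the reference point of the series. In an ADME assay on NIH3T3 cells (Mus musculus) for cytotoxicity, read by XTT assay, with a stated time of 24 h (a lower number here means a stronger inhibitor, a higher number a weaker inhibitor), compound 1 gives > 500 ug/mL, which is a limit of the assay and not a number. Compound 2 `Fc1ccc(C2CC(c3ccc(Cl)s3)=NN2c2nc(-c3ccccc3)cs2)cc1` gives > 500 ug/mL in this assay, again a limit. Compound 3 `Fc1ccc(-c2csc(N3N=C(c4ccc(Cl)s4)CC3c3ccc(F)cc3)n2)cc1` gives > 500 ug/mL in this assay, also a limit. Within the data shown here, the two measured steps are therefore a step that the two limits leave unreadable from compound 1 to compound 2 and a step that the two limits leave unreadable from compound 2 to compound 3; neither can be sized, since the limit of > 500 ug/mL in this assay, at which 3 of the 3 values shown sit, holds for every value so far.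

Compound 4 `Cc1ccc(C2=NN(c3nc(-c4ccc(C#N)cc4)cs3)C(c3ccc(F)cc3)C2)s1` differs from compound 1 by cyano in place of hydrogen on an aromatic carbon. Among the measured compounds shown here, no measured step covers this change, and the two steps that exist only show that chloro for methyl and fluoro for hydrogen left every value at the limit. There is nothing in the series that points to a readable step in either direction in this assay, so no change beyond the scatter is expected here, and the step that the limit leaves unreadable from compound 1 to compound 4 is expected to stay unreadable. Compound 4 is accordingly expected to sit at 600 ug/mL, with a range from 250 ug/mL to 1500 ug/mL, most likely reported once more as a limit.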

Compound 4, half-maximal inhibitory concentration: 250 ug/mL
Compound 4: middle estimate off by 2.4-fold (0.38 log units), on the high side; the measured number falls inside the stated range.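

Cyano in place of hydrogen on the phenyl gives an at least 2.0-fold lower number from compound 1 to compound 4 (0.30 log units; that floor lies within the scatter), the first step in the series that carries any size, and that size is only a floor. Compound 4 is also the only compound shown with a number and not a limit in this assay, while the earlier steps, including fluoro in place of hydrogen, cannot be read: the limit of > 500 ug/mL in this assay, at which 3 of the 4 values shown sit. With the floor inside the scatter, the step does not establish a real shift, but it does show that a substituent at this position, on an aromatic carbon of the phenyl and para to a large group, can bring the read-out to a measurable number.

As far as these compounds go, whether that number is specific to cyano or would also appear with another group at this position, such as an amine, a carboxylic acid or a methoxy group, stays open. Among these compounds, also open is whether cyano gives a readable number on compound 2, which carries chloro in place of the methyl of compound 1, since the series holds no such pair.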